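Bromo in Place of Chloro Near the Assay Limit

The compounds below may be only part of what the source reports. "The series", "measured", "known", "first", "only" and "open" are said of these compounds alone.

Of the compounds shown here, three sharing one core have been measured in a functional assay on K562 cells (Homo sapiens) for cytotoxicity, read by MTT assay, with a stated time of 24 h; a higher number here means a weaker inhibitor, a lower number a stronger inhibitor. Compound 1 (`CN1C/C(=C\c2cccc([N+](=O)[O-])c2)C(=O)/C(=C/c2ccccc2F)C1`) gives 3890 nM, and compound 2 (`CN1C/C(=C\c2ccc(F)cc2)C(=O)/C(=C/c2cccc([N+](=O)[O-])c2)C1`) gives 11300 nM. Compound 3 (`CN1C/C(=C\c2ccc(Cl)cc2)C(=O)/C(=C/c2cccc([N+](=O)[O-])c2)C1`) gives only a limit, > 20000 nM, and no number. This is the limit of > 20000 nM in this assay, at which 1 of the 3 values shown sits.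

Compound 4 (`CN1C/C(=C\c2ccc(Br)cc2)C(=O)/C(=C/c2cccc([N+](=O)[O-])c2)C1`) differs from compound 3 by bromo in place of chloro on an aromatic carbon, para to a large group.

Going by the values given here, the closest precedent is the halogen exchange at the same place, an at least 1.7-fold higher number from compound 2 to compound 3 (0.24 log units; that floor lies within the scatter). That step is only a floor, and it does not go beyond the scatter. Moving from the 2-fluorophenyl of compound 1 gave larger steps, a 2.9-fold higher number from compound 1 to compound 2 (0.46 log units; beyond the scatter) and an at least 5.1-fold higher number from compound 1 to compound 3 (0.71 log units; beyond the scatter), but these also change the place of the halogen, so they bear on the present exchange only indirectly. On the precedent of compound 3 at > 20000 nM, no step beyond the scatter is expected in this assay, and compound 4 may also report only a limit. The expected change is a number no higher from compound 3 to compound 4 (the limit leaves the size open). For compound 4 the estimated value is 20000 nM, with an expected range from 9000 nM to 45000 nM.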

Compound 4, half-maximal inhibitory concentration: > 20000 nM
Compound 4 gave a limit, no number; the forecaster's own chance of this, stated with the estimate: 50%; the middle value lies on the limit itself.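

In this assay compound 4 gives only a limit, > 20000 nM, so the 4-chlorophenyl to 4-bromophenyl exchange, para to a large group, yields no readable number, and the step between compound 3 and compound 4 cannot be read. Bromo in place of fluoro at this position gives an at least 1.7-fold higher number from compound 2 to compound 4 (0.24 log units; that floor lies within the scatter), so the comparison with the fluoro compound still shows no separation beyond the scatter. Replacing the 2-fluorophenyl with 4-bromophenyl gives an at least 5.1-fold higher number from compound 1 to compound 4 (0.71 log units; beyond the scatter), so bromo now joins chloro in a floor beyond the scatter against compound 1, and the limit recurs in this series: the limit of > 20000 nM in this assay, at which 2 of the 4 values shown sit.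

The compounds shown leave open where compound 3 and compound 4 truly stand, and so whether chloro and bromo differ at all at this position. Going by these compounds, it also remains open whether a methoxy group or an amine on this aromatic carbon would return a number within the readable range of this assay, which would give the series a measured comparison at this position beyond the fluoro compound.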